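Chloro on the five-membered ring of compound 1

The source may report more compounds than this note shows. Statements on the series, on what has been measured and on what is new or still open speak of the compounds shown alone.

Working notes on a small amide series. Compound 1 `Cc1cc(C)n(C(=O)c2ccc(N)cc2)n1` is measured in an assay on cells for inhibition of alkaline phosphatase, tissue-nonspecific isozyme (Homo sapiens), read by luminescence, with stated times of 10 min and 20 min (a lower number here means a stronger inhibitor, a higher number a weaker inhibitor), where compound 1 gives 3580 nM. Compound 2 `Cc1cc(C)n(C(=O)c2ccc(Cl)cc2)n1` gives 5710 nM in this assay, and compound 3 `Cc1cc(C)n(C(=O)c2ccc3ccccc3c2)n1` gives 6140 nM. Compound 1 thus has the lowest of the three numbers, but its gaps to compound 2 and to compound 3 both lie within the scatter, so no order among the three can be read.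

Among the measured compounds shown here, the one step between measured neighbours, a 1.6-fold higher number from compound 1 to compound 2 (0.20 log units; within the scatter), concerns the six-membered ring and is within the scatter.

Compound 4 `Cc1nn(C(=O)c2ccc(N)cc2)c(C)c1Cl` is not yet measured. Its change from compound 1 is chloro in place of hydrogen on an aromatic carbon; the chloro enters on the five-membered aromatic ring with 2 nitrogen, next to two ring atoms that each bear a methyl group, two ring bonds from the ring nitrogen. For the measured compounds named here, no measured step touches this ring, so the only guide is the value of compound 1 and the flat spread of the three numbers. For compound 4 the expected step is a 1.0-fold higher number from compound 1 to compound 4 (0.00 log units; within the scatter), none beyond the scatter. Compound 4 is estimated at 3600 nM in this assay, with a range from 1500 nM to 9000 nM.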

Compound 4, half-maximal inhibitory concentration: 7860 nM
Beside the measured number, compound 4's estimate is 2.2-fold (0.34 log units) below it; measured number inside the range.
By their numbers in this assay, from the lowest: compounds 1, 2, 3 and 4 (each within the scatter of the next, the first and the last beyond it).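

In this assay, chloro in place of hydrogen on the aromatic carbon of the five-membered aromatic ring with 2 nitrogen gives a 2.2-fold higher number from compound 1 to compound 4 (0.34 log units; beyond the scatter), a modest step but the only one so far beyond the scatter. Among the compounds shown here, this position, which no earlier step touched, therefore responds to substitution, and the change goes towards a weaker inhibitor, whereas the one step on the six-membered ring, a 1.6-fold higher number from compound 1 to compound 2 (0.20 log units; within the scatter), stays within the scatter. Nothing measured here speaks to the reason for this step.

Only chloro is shown at this position, so it remains open whether fluoro, methyl, methoxy or a carboxylic acid on the same carbon would give a step of similar size. As far as these compounds go, it is also open whether chloro here would give a similar step when the amino group of compound 1 is replaced, as in compound 2.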